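The source may report more compounds than this note shows. Statements on the series, on what has been measured and on what is new or still open speak of the compounds shown alone.

Compound 1 `CC1=CC[C@@H]([C@@](C)(O)CCCC(C)(C)NC=S)CC1` and compound 2 `CC1=CC[C@@H]([C@@](C)(O)CCCC(C)(C)NC(=S)N/N=C\c2ccc(N(C)C)cc2)CC1` share the same core, and both were tested in a functional assay on K562 cells (Homo sapiens) for cytotoxicity, read by sulforhodamine B assay (a lower number here means a stronger inhibitor of growth, a higher number a weaker inhibitor of growth), against a human leukaemia cell line. Compound 1 reaches only a limit of the assay, > 100000 nM, rather than a measured number. In this assay, going by the values given here, compound 2 gives 42000 nM, the only actual number among the two values shown, the other being (the limit of > 100000 nM in this assay, at which 1 of the 2 values shown sits). Compound 3 `CC1=CC[C@@H]([C@@](C)(O)CCCC(C)(C)NC(=S)N/N=C\c2cccc(Cl)c2)CC1` keeps all of compound 2 except the aromatic group on the carbon with a double bond to nitrogen: 3-chlorophenyl in place of 4-(dimethylamino)phenyl on a carbon with a double bond to nitrogen. Among the compounds with values here, no pair of measured compounds shows what such a swap does in this assay, so there is no measured step to set the size of this change by. From compound 2 to compound 3 the change is expected to stay within the usual scatter of this assay, a 1.1-fold lower number from compound 2 to compound 3 (0.02 log units; within the scatter), with no clear push toward stronger or weaker growth inhibition. Compound 3 is therefore estimated in this assay at 40000 nM, with a likely range from 12000 nM to 120000 nM.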

Compound 3, concentration for total growth inhibition: 1060 nM
Compound 3: middle estimate off by 38-fold (1.58 log units), on the high side, and the stated range ends above it.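

In this assay the aromatic group on the carbon with a double bond to nitrogen proves to matter a great deal: 3-chlorophenyl in place of 4-(dimethylamino)phenyl gives a 40-fold lower number from compound 2 to compound 3 (1.60 log units; beyond the scatter) at this one place, while the rest of the molecule stays the same. The earlier compounds shown here could not show this, since compound 1 has no such aromatic group and reached only a limit, and compound 2 alone offered no measured step for comparing one aromatic group with another. The result therefore marks this aromatic group as a place where a single swap can shift growth inhibition well beyond the usual scatter, but no measurement shown gives a reason for the size of this step.

On these data alone, what stays open is which part of the swap carries the step: the arrival of the chlorine or the departure of the dimethylamino group. A plain phenyl group at this place, or a fluorine or a methoxy group in place of the chlorine, would help to separate those two parts.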